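The source may hold more compounds than are shown below. What is called first, only, known or untested is meant among the compounds shown, and "the series" means these compounds.

Compound 1 `Cc1ccccc1-n1nncc1CN1C(=O)C2(C(C#N)=C(N)Oc3c2c2nc4ccccc4nc2c2ccccc32)c2ccccc21` and compound 2 `Cc1ccc(C)c(-n2nncc2CN2C(=O)C3(C(C#N)=C(N)Oc4c3c3nc5ccccc5nc3c3ccccc43)c3ccccc32)c1` share one core and were both tested in a functional assay on A549 cells (Homo sapiens) for antiproliferative activity, read by MTT assay, with a stated time of 48 h; on this read-out higher numbers stand for weaker inhibition and lower numbers for stronger inhibition. In this assay compound 1 gives > 50000 nM, which is a limit of the assay rather than a number. In this assay compound 2 likewise gives > 50000 nM, again only a limit. The step that the two limits leave unreadable from compound 1 to compound 2 therefore has no readable size, because both of its ends sit at the limit of > 50000 nM in this assay, at which 2 of the 3 values shown sit. Compound 3 `Cc1cccc(-n2nncc2CN2C(=O)C3(C(C#N)=C(N)Oc4c(N)cc5nc6ccccc6nc5c43)c3ccccc32)c1` is the only one of the three with a measured number: in this assay compound 3 gives 12300 nM.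

Compound 4 `N#CC1=C(N)Oc2c(N)cc3nc4ccccc4nc3c2C12C(=O)N(Cc1cnnn1-c1ccccc1Br)c1ccccc12` has not yet been measured. It differs from compound 3 by 2-bromophenyl in place of 3-methylphenyl on an aromatic nitrogen. Within the data shown here, no measured step shows what exchanging this aryl group does; the single recorded step lies between two limits and offers no size. With no guide, the step expected in this assay is a 1.2-fold higher number from compound 3 to compound 4 (0.09 log units; within the scatter), within the usual scatter. Compound 4 is therefore estimated at 15000 nM, with a range from 5000 nM to 50000 nM.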

Compound 4, half-maximal inhibitory concentration: 27400 nM
The estimate for compound 4 lay 1.8-fold (0.26 log units) below the measured number; low and high end bracket the measured number.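

In this assay, the aryl group on the aromatic nitrogen now has a readable effect: exchanging 3-methylphenyl for 2-bromophenyl gives a 2.2-fold higher number from compound 3 to compound 4 (0.35 log units; beyond the scatter). The group held at this position can therefore move the number, and here the exchange brings a modest loss of inhibition, while compound 4 still gives a measured number rather than a limit. The only earlier step could not show this, since neither of its ends gives a number: the limit of > 50000 nM in this assay, at which 2 of the 4 values shown sit.

This one exchange replaces the methyl with a bromine and also changes where the group sits on the phenyl ring, so the compounds shown cannot separate those two changes. Also open, as far as these compounds go, is how a 3-bromophenyl, a 2-methylphenyl, or a phenyl ring carrying an amine or a carboxylic acid would behave at this position.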